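Methoxy on the ethylamide chain of compound 1

The source may report more compounds than this note shows. Statements on the series, on what has been measured and on what is new or still open speak of the compounds shown alone.

Compound 1 `CCNC(=O)c1cc(C(=O)NC)c(=O)n(Cc2ccccc2)c1` has been measured in a physicochemical assay for lipophilicity, at pH 7.4 (on this read-out lower numbers stand for lower lipophilicity and higher numbers for higher lipophilicity), where compound 1 gives 3. Two other members of the series have values in this assay. Compound 2 `CNC(=O)c1cc(C(=O)NC2CCC2)cn(Cc2cccc(NC)c2)c1=O` gives 3.6, a number higher than that of compound 1 by a margin beyond the usual scatter. Compound 3 `CNC(=O)c1cc(C(=O)NC2CC2)cn(CC2CCOCC2)c1=O` gives 1.5, a number lower than that of compound 1 by a margin well beyond the scatter. Compound 1 thus stands second highest of the three values in hand, closer to compound 2 than to compound 3.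

Compound 4 `CNC(=O)c1cc(C(=O)NCCOC)cn(Cc2ccccc2)c1=O` has not yet been measured in this assay. It differs from compound 1 in one place: methoxy in place of hydrogen on a saturated chain carbon, two bonds along the chain from an amide-type nitrogen. Within the data shown here, no measured pair is separated by this same change, so there is no measured step to lean on; the expectation rests on the values of compounds 1, 2 and 3 alone. For compound 4 a small downward step is expected, a number 0.40 log units lower from compound 1 to compound 4 (beyond the scatter), of a size only modestly beyond the scatter. The estimate for compound 4 in this assay is 2.6, with a range from 2.1 to 3.1.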

Compound 4, distribution coefficient: 2.7
Compound 4: middle estimate off by 0.10 log units, on the low side; low and high end bracket the measured number.
By their numbers in this assay, from the lowest: compound 3; then compounds 4 and 1 (each within the scatter of the next); then compound 2.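

In this assay, among these compounds, the change now has a measured step of its own, a number 0.30 log units lower from compound 1 to compound 4 (within the scatter), and it is the only step so far. Compounds 2 and 3 differ from compound 1 in more than one place, so they could not isolate this change; the new pair shows that methoxy in place of hydrogen on a saturated chain carbon, two bonds along the chain from an amide-type nitrogen, leaves compound 4 within the scatter of compound 1. Nothing in hand accounts for the size of this step.

Going by these compounds, whether a terminal amine, a carboxylic acid or a longer chain ending in methoxy at this place would move the number beyond the scatter remains open. Also open, on these data alone, is whether methoxy gives a similar step on compounds with other groups elsewhere on the shared core.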